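The compounds below may be only part of what the source reports. "The series", "measured", "known", "first", "only" and "open" are said of these compounds alone.

In an assay for inhibition of Nicotinamide phosphoribosyltransferase (Homo sapiens), read by mass spectrometry, with stated times of 15 min and 30 min (on this read-out lower numbers stand for stronger inhibition and higher numbers for weaker inhibition), compound 1 `O=C(NCc1ccc(S(=O)(=O)c2ccccc2)cc1)c1cc2ncccc2s1` gives 400 nM, compound 2 `O=C(NCc1ccc(S(=O)(=O)c2ccccc2)cc1)c1nc2ccncc2s1` gives 210 nM and compound 3 `O=C(NCc1ccc(S(=O)(=O)c2ccccc2)cc1)c1ccc2nccn2c1` gives 18 nM, the lowest number of the three and the most potent, since both steps to it lie beyond the scatter. The steps of a 22-fold lower number from compound 1 to compound 3 (1.35 log units; beyond the scatter) and a 12-fold lower number from compound 2 to compound 3 (1.07 log units; beyond the scatter) are large, whereas a 1.9-fold lower number from compound 1 to compound 2 (0.28 log units; within the scatter).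

Compound 4 `O=C(NCc1ccc(S(=O)(=O)c2ccccc2)cc1)c1ccc2nncn2c1` carries a group of 9 heavy atoms (6 carbon, 3 nitrogen; one five-membered aromatic ring with 3 hetero atoms, one six-membered aromatic ring with 1 hetero atom) in place of a group of 9 heavy atoms (7 carbon, 2 nitrogen; one five-membered aromatic ring with 2 hetero atoms, one six-membered aromatic ring with 1 hetero atom), on a carbonyl carbon. Among the measured compounds shown here, no measured step makes this exchange; the three measured steps, all on the same carbonyl carbon, show that swaps of this group range from within the scatter to large. Lacking a direct precedent, a modest step is expected from compound 3 to compound 4 in this assay, a 1.9-fold higher number from compound 3 to compound 4 (0.29 log units; within the scatter), toward a higher number. In this assay compound 4 is therefore estimated at 35 nM, with an expected range from 10 nM to 150 nM.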

Compound 4, half-maximal inhibitory concentration: 370 nM
Compound 4: the middle estimate sits 11-fold (1.02 log units) below what was measured; the measured number lies above the stated range.
By their numbers in this assay, from the lowest: compound 3; then compounds 2, 4 and 1 (each within the scatter of the next).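

At this carbonyl carbon, a five-membered aromatic ring with 3 hetero atoms in place of one with 2 hetero atoms, a single carbon exchanged for nitrogen, removes the advantage of compound 3 in this assay: a 21-fold higher number from compound 3 to compound 4 (1.31 log units; beyond the scatter). Compound 4 instead joins the two sulfur-bearing compounds, with a 1.8-fold higher number from compound 2 to compound 4 (0.25 log units; within the scatter) and a 1.1-fold lower number from compound 1 to compound 4 (0.03 log units; within the scatter), so that only compound 3 stands apart. No available data account for this loss.

Open, from the compounds shown here alone, is whether compound 3 keeps its number when a methyl or a chlorine is added to its group, and whether the gap between compound 3 and compound 4 survives replacing the shared phenyl ring on the sulfonyl with a morpholine.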